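The source may report more compounds than this note shows. Statements on the series, on what has been measured and on what is new or still open speak of the compounds shown alone.

Compound 1 `O=C(O)CC1CNC(=O)c2cc(Br)c(Br)n21` and compound 2 `COC(=O)CC1CNC(=O)c2cc(Br)c(Br)n21` share one core. In a functional assay on PC-3 cells (Homo sapiens) for cytotoxicity, read by CCK-8 assay, with a stated time of 72 h (a lower number here means a stronger inhibitor, a higher number a weaker inhibitor), compound 1 gives only a limit, > 200000 nM, and no number. In this assay compound 2 gives 79000 nM, the only number shown among these compounds. For the measured compounds named here, the single measured step is an at least 2.5-fold lower number from compound 1 to compound 2 (0.40 log units; beyond the scatter), and compound 1 sits at the limit of > 200000 nM in this assay, at which 1 of the 2 values shown sits. Compound 3 `CCOC(=O)CC1CNC(=O)c2cc(Br)c(Br)n21` differs from compound 2 by methyl in place of hydrogen on a saturated chain carbon bound to an oxygen next to a carbonyl group, read one bond further out as methyl to ethyl, methoxy to ethoxy, methoxycarbonyl to ethoxycarbonyl. That step bears on the change to compound 3 only loosely, because an at least 2.5-fold lower number from compound 1 to compound 2 (0.40 log units; beyond the scatter) concerns the hydrogen on the oxygen next to the carbonyl group rather than growth of the chain carbon bound to it. Going by the values given here, for the step from compound 2 to compound 3 no measured step exists. In this assay compound 3 is expected to show a 1.3-fold lower number from compound 2 to compound 3 (0.12 log units; within the scatter), a change not beyond the scatter. Compound 3 is estimated at 60000 nM, within a range from 25000 nM to 150000 nM.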

Compound 3, half-maximal inhibitory concentration: 39000 nM
For compound 3 the middle estimate is 1.5-fold (0.19 log units) above the measured one, and the stated range covers the measured number.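

The ethyl ester shows that this position responds to growth of the chain itself: in this assay the change from methoxycarbonyl to ethoxycarbonyl gives a 2.0-fold lower number from compound 2 to compound 3 (0.31 log units; beyond the scatter), a step on the saturated chain carbon rather than on the oxygen. Measured against the free carboxylic acid, ethyl in place of hydrogen on the oxygen next to a carbonyl group gives an at least 5.1-fold lower number from compound 1 to compound 3 (0.70 log units; beyond the scatter), so the two ester steps run the same way. Compound 1 still gives a limit and not a number: the limit of > 200000 nM in this assay, at which 1 of the 3 values shown sits.

The compounds shown leave open whether a longer chain, such as propyl or butyl, or a branched isopropyl group would continue this trend. They also leave open how an amide formed from an amine at this carbonyl would read in this assay.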